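Aziridinylquinone side chains: carbamate to methoxypropyl

The compounds below may be only part of what the source reports. "The series", "measured", "known", "first", "only" and "open" are said of these compounds alone.

Measured compounds:
Compound 1 `CC1=C(N2CC2)C(=O)C(CC(C)OC(N)=O)=C(N2CC2)C1=O` gives 5.18 in a functional assay on L1210 cells (Mus musculus), with a stated time of 1 days; on this read-out higher numbers stand for higher potency (the scale is a negative logarithm) and lower numbers for lower potency.
Compound 2 `CCOC(COC(N)=O)C1=C(N2CC2)C(=O)C(C)=C(N2CC2)C1=O` gives 4.62 in this assay.
Compound 3 `CC1=C(N2CC2)C(=O)C(C(C)COC(N)=O)=C(N2CC2)C1=O` gives 5.31 in this assay.

Compound 3 stands highest of the three numbers in this assay, though compound 1 lies only a number 0.13 log units higher from compound 1 to compound 3 (within the scatter) and the two are within the scatter of each other. Compound 2 lies further off, with a number 0.69 log units higher from compound 2 to compound 3 (beyond the scatter).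

Compound 4 `CCC(OC)C1=C(N2CC2)C(=O)C(C)=C(N2CC2)C1=O` differs from compound 3 in one place: a group of 5 heavy atoms (4 carbon, 1 oxygen; no ring) in place of a group of 7 heavy atoms (4 carbon, 1 nitrogen, 2 oxygen; no ring), on a double-bonded ring carbon. Going by the values given here, the step from compound 2 to compound 3, a number 0.69 log units higher from compound 2 to compound 3 (beyond the scatter), bears on this change in part, since it also touches the saturated chain carbon bound to the ring, but in compound 4 the carbamate leaves altogether and a methoxy group enters on that chain carbon, a change no measured pair covers directly. The step of a number 0.13 log units higher from compound 1 to compound 3 (within the scatter) shows that moving the carbamate within the chain mattered little. With the carbamate gone and an alkoxy group on the chain carbon, as in compound 2, a modest drop in this assay is expected for compound 4, amounting to a number 0.51 log units lower from compound 3 to compound 4 (beyond the scatter). Compound 4 is therefore estimated at 4.8, within a range from 4.3 to 5.3.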

Compound 4, logarithm of the reciprocal of the active concentration, log(1/C): 4.84
Beside the measured number, compound 4's estimate is 0.04 log units below it, and the stated range covers the measured number.
By their numbers in this assay, from the lowest: compounds 2 and 4 (each within the scatter of the next); then compounds 1 and 3 (each within the scatter of the next).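

Going by these compounds alone, all three earlier compounds carried the carbamate on their side chains, so compound 4 is the first here to show what happens at this double-bonded ring carbon without it. In this assay the 1-methoxypropyl group gives a number 0.47 log units lower from compound 3 to compound 4 (beyond the scatter) and a number 0.34 log units lower from compound 1 to compound 4 (beyond the scatter); both steps lie beyond the scatter but are modest, so the carbamate adds to the read-out yet is not required for a measurable potency, since compound 4 still gives 4.84 with no hydrogen-bond donor in its side chain. No measurement at hand explains this drop.

The change removes the carbamate and places a methoxy group on the chain carbon bound to the ring in one move, so the compounds shown leave open how much of the step belongs to each part. A plain propyl chain, or a hydroxy group or an amine in place of the methoxy group on that carbon, would separate the two contributions and show whether the oxygen of the 1-methoxypropyl group matters at this position at all.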